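The compounds below may be only part of what the source reports. "The series", "measured", "known", "first", "only" and "open" are said of these compounds alone.

Compound 1 `Cc1ccc(N2C(=O)CSC2c2sc(Cc3ccc(Cl)cc3)nc2C)cc1` was tested in a functional assay on the whole organism (strain Wistar albino) for inhibition, with Rattus norvegicus as the target, read by paw edema, with a stated time of 1 h, at a dose of 40 mg/kg by the oral route (on this read-out lower numbers stand for less inhibition and higher numbers for more inhibition at the one dose given (going by the name of the read-out)), and gave 59.9%. On the numbers at hand, compound 1 stands lowest of two, its nearest neighbour being compound 2 `Cc1nc(-c2ccc(Cl)cc2)sc1C1SCC(=O)N1c1ccc(F)cc1`, which in this assay gives 63.4%, a gap within the scatter. For the measured compounds named here, no step between measured compounds is available. The change to compound 3 `Cc1nc(Cc2ccc(Cl)cc2)sc1C1SCC(=O)N1c1ccccc1` is hydrogen in place of methyl on an aromatic carbon; cut one bond further out, it reads 4-methylphenyl to phenyl. With only the two measured values as a guide, the expected step in this assay is a number 1.9 percentage points lower from compound 1 to compound 3 (within the scatter), none beyond the scatter. Compound 3 is therefore estimated at 58%, within 45% to 70%.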

Compound 3, a percentage reported as inhibition, in the whole organism at one dose (the size of the read-out at that dose, not a potency): "not active" (no number reported)
The entry for compound 3 holds no number; the estimate stays without a comparison.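

For the compounds shown here, compound 3 is entered as "not active" in this assay, without a number, so no step from compound 1 to compound 3 can be read. The compounds shown leave open how far the change from 4-methylphenyl to phenyl moves this read-out. No evidence at hand bears on this result.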